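The source may report more compounds than this note shows. Statements on the series, on what has been measured and on what is new or still open speak of the compounds shown alone.

Compound 1 `c1cnc(-c2ccccc2OCC2=NCCN2)nc1`: 1260 nM
Compound 2 `c1ccc(-c2nccs2)c(OCC2=NCCN2)c1`: 2.51 nM

In a functional assay for activation of Alpha-1A adrenergic receptor (Homo sapiens), read by calcium flux (on this read-out higher numbers stand for an effect only at larger amounts of compound and lower numbers for an effect already at smaller amounts), compound 2 gives the lowest of the two numbers; its nearest neighbour is compound 1, and the step of a 500-fold lower number from compound 1 to compound 2 (2.70 log units; beyond the scatter) shows how far apart they lie. Compound 3 `Cc1ccoc1-c1ccccc1OCC1=NCCN1` differs from compound 2 in one place: 3-methylfuran-2-yl in place of 1,3-thiazol-2-yl on an aromatic carbon. Among the compounds with values here, the only measured step, from compound 1 to compound 2, exchanged pyrimidin-2-yl for 1,3-thiazol-2-yl and was large; here one five-membered aromatic ring replaces another, so that step is only a loose guide. The expected step of a 2.0-fold higher number from compound 2 to compound 3 (0.30 log units; within the scatter) is a slight rise, within the scatter. Compound 3 is estimated at 5 nM, between 1.2 nM and 25 nM.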

Compound 3, half-maximal effective concentration: 3.16 nM
Beside the measured number, compound 3's estimate is 1.6-fold (0.20 log units) above it; the measured number falls inside the stated range.
By their numbers in this assay, from the lowest: compounds 2 and 3 (each within the scatter of the next); then compound 1.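

In this assay the five-membered aromatic ring on this carbon can go from 1,3-thiazol-2-yl, with its 2 hetero atoms, to 3-methylfuran-2-yl, with 1 hetero atom, at only (a 1.3-fold higher number from compound 2 to compound 3 (0.10 log units; within the scatter)). So the nitrogen and sulfur of the thiazole are not required for a low number here. The large gap to pyrimidin-2-yl also holds for this second ring (a 400-fold lower number from compound 1 to compound 3 (2.60 log units; beyond the scatter)). Nothing available explains these differences. From the compounds shown here alone, how furan-2-yl without the methyl, a phenyl ring or an amine on this carbon would read stays open.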